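Moving the Nitrile: From 4-Cyanophenyl to 3-Cyanophenyl

A few compounds are considered here, and "the series" means these few. Any claim that something is new, unique, unknown or untested is made for them only; others in the source may bear on it.

In a functional assay on HL-60 cells (Homo sapiens) for inhibition, read by MTT assay, with a stated time of 72 h, tested at 50 uM (on this read-out lower numbers stand for less inhibition of growth and higher numbers for more inhibition of growth at the one concentration tested), compound 1 (`C=CCc1cc(O)c(O)c(CN2CCC(CCO)CC2)c1`) gives 52.1% and compound 2 (`C=CCc1ccc(OCc2cn(-c3ccc(C#N)cc3)nn2)c(O)c1`) gives 31.8% as the lower of the two numbers, a gap to compound 1 that lies beyond the usual scatter. Among the compounds with values here, no step between measured compounds that differ in one place is available so far.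

Compound 3 (`C=CCc1ccc(OCc2cn(-c3cccc(C#N)c3)nn2)c(O)c1`) has the same atoms as compound 2, joined differently, with 3-cyanophenyl in place of 4-cyanophenyl on an aromatic nitrogen of a five-membered aromatic ring with 3 nitrogen. The counted difference, (3-cyanophenyl in place of 4-cyanophenyl on an aromatic nitrogen), leaves the two groups matched in every count.

Within the data shown here, no measured pair shows what this move does, so the expectation in this assay is a step of no size beyond the scatter, with no direction favoured. That expectation takes compound 2 at 31.8% as its anchor. The estimated change is a number 1.2 percentage points higher from compound 2 to compound 3 (within the scatter) and would stay within the scatter. The expected value for compound 3 is 33% (estimated range 19% to 47%) in this assay when it is measured.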

Compound 3, percent growth inhibition at one concentration: 30.9%
For compound 3 the middle estimate is 2.1 percentage points above the measured one; the range from low to high includes it.
By their numbers in this assay, from the lowest: compounds 3 and 2 (each within the scatter of the next); then compound 1.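

Within the data shown here, putting 3-cyanophenyl in place of 4-cyanophenyl on the aromatic nitrogen gives the first comparison in this set between compounds that differ in one place, and in this assay it comes to a number 0.9 percentage points lower from compound 2 to compound 3 (within the scatter). At the one concentration tested, the two cyanophenyl groups therefore cannot be told apart, so for this pair the placement of the nitrile on the phenyl ring leaves no mark on the read-out that stands clear of the scatter. No measurement at hand offers an explanation for this result.

The compounds shown leave open whether the same level would hold if the nitrile on this phenyl ring gave way to another group, such as an amine or a carboxylic acid, or if the ring were a plain phenyl with nothing on it. Also open, going by these compounds, is whether compound 2 and compound 3 would still match at other concentrations or on other cells, as the present comparison rests on a single concentration in a single cell line.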